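A few compounds are considered here, and "the series" means these few. Any claim that something is new, unique, unknown or untested is made for them only; others in the source may bear on it.

In an assay on HEK-293T cells for inhibition of diacylglycerol lipase-alpha (Homo sapiens), read by colorimetric assay (on this read-out lower numbers stand for stronger inhibition and higher numbers for weaker inhibition), compound 3, with the structure `O=C(CCCCCCc1ccccc1)c1nc(C(=O)C(F)(F)F)co1`, gives 123 nM, the lowest of the two numbers recorded. Compound 1, `O=C(CCCCCc1ccccc1)c1nc2cc(F)ccc2o1`, gives 1410 nM in this assay, a higher number by a margin that lies beyond the usual scatter. Compound 2, `O=C(CCCCCCc1ccccc1)c1nnn(-c2cccs2)n1`, reaches only > 10000 nM in this assay, which is a limit of the assay and not a number; this is the situation described as the limit of > 10000 nM in this assay, at which 1 of the 3 values shown sits.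

The next compound, compound 4, has the structure `CNC(=O)c1coc(C(=O)CCCCCCc2ccccc2)n1`. It differs from compound 3 in one place, (methylamino in place of trifluoromethyl on a carbonyl carbon). Cut one bond further out, the change reads as (trifluoromethyl)carbonyl to methylcarbamoyl, so the carbonyl carbon keeps its aromatic carbon neighbour while the trifluoromethyl gives way to methylamino.

Among the compounds with values here, no measured pair among the three compounds shares this change, so there is no step to lean on. Compound 4 is nonetheless expected to give a higher number than compound 3 in this assay, a step of a 24-fold higher number from compound 3 to compound 4 (1.39 log units; beyond the scatter) beyond the scatter. Compound 4 is estimated at 3000 nM, between 600 nM and 15000 nM.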

Compound 4, half-maximal inhibitory concentration: > 10000 nM
Compound 4 gave a limit, no number; the forecaster's own chance of this, stated with the estimate: 35%; at least 3.3-fold (0.52 log units) between middle value and limit.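

In this assay, within the data shown here, putting methylamino in place of trifluoromethyl on a carbonyl carbon gives an at least 81-fold higher number from compound 3 to compound 4 (1.91 log units; beyond the scatter), the only step here between compounds that differ in one place, which shows that the activity of compound 3 depends strongly on what sits at this position. Compound 4 gives > 10000 nM, which is a limit of the assay and not a number, so the step has a known minimum but no known full size. The earlier compounds showed nothing about this position, and the limit is now reached by more of the series: the limit of > 10000 nM in this assay, at which 2 of the 4 values shown sit.

The compounds shown leave open whether the loss comes from removing trifluoromethyl or from adding methylamino, which a methyl ketone, a methyl ester or a carboxylic acid at this carbonyl carbon could help to separate. They also leave open whether a dimethylamino group, which lacks the amide hydrogen, would behave like methylamino.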